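Swapping Chloro for Bromo in a Pair of Growth Inhibitors

A few compounds are considered here, and "the series" means these few. Any claim that something is new, unique, unknown or untested is made for them only; others in the source may bear on it.

Of the compounds shown here, three have been measured in a functional assay on MCF7 cells (Homo sapiens) for cytotoxicity, read by sulforhodamine B assay, with a stated time of 48 h; a lower number here means a stronger inhibitor of growth, a higher number a weaker inhibitor of growth. Compound 1 `O=C1C(=O)N(CN2CCN(c3ccnc4cc(Cl)ccc34)CC2)c2cccc(Cl)c21` gives 39100 nM and compound 2 `O=C1C(=O)N(CN2CCN(c3ccnc4cc(Cl)ccc34)CC2)c2cccc(Br)c21` gives 15100 nM. The two share a core and differ in one place: bromo in place of chloro on an aromatic carbon. That change produced a 2.6-fold lower number from compound 1 to compound 2 (0.41 log units; beyond the scatter).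

Compound 3 `O=C1C(=O)N(CN2CCN(c3ccnc4cc(C(F)(F)F)ccc34)CC2)c2cc(Cl)ccc21` gives 15800 nM in this assay. Its core is not the core of compound 1, and the difference between the two cores is not broken down here. Compound 3 sits a lower number than compound 1, beyond the scatter, while its value and that of compound 2 lie within the scatter of each other.

Compound 4 `O=C1C(=O)N(CN2CCN(c3ccnc4cc(C(F)(F)F)ccc34)CC2)c2cc(Br)ccc21` has not yet been measured. It differs from compound 3 in one place: bromo in place of chloro on an aromatic carbon. Among the compounds with values here, this is the same kind of change as the one from compound 1 to compound 2, but not the same: in that pair the place was ortho to a fused ring and meta to a fused ring, whereas here it is meta to a fused ring and para to a fused ring.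

The step from compound 3 to compound 4 is expected to be a 2.0-fold lower number from compound 3 to compound 4 (0.30 log units; within the scatter) in this assay, a somewhat smaller move than the earlier one, because a 2.6-fold lower number from compound 1 to compound 2 (0.41 log units; beyond the scatter) came from a different position on the core and rests on a single pair. Compound 4 is expected to give 8000 nM, within a range from 3500 nM to 20000 nM.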

Compound 4, concentration for 50% growth inhibition: 28100 nM
The estimate for compound 4 lay 3.5-fold (0.55 log units) below the measured number; the whole stated range lies below it.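

In this assay, bromo in place of chloro on the core of compound 3 reads as a 1.8-fold higher number from compound 3 to compound 4 (0.25 log units; within the scatter), so on this core the swap cannot be told apart from the ordinary spread of repeated measurements. The swap therefore does not carry a fixed size from one core to the other, and the clear shift seen on the first core cannot simply be applied to the second: the same change on two cores in this assay, a 2.6-fold lower number (0.41 log units; beyond the scatter) from compound 1 to compound 2 and a 1.8-fold higher number (0.25 log units; within the scatter) from compound 3 to compound 4, 4.6-fold (0.66 log units) apart, beyond the scatter of two such steps. What this does not show is the reason for the gap, since the two pairs differ both in where the halogen sits and in having trifluoromethyl rather than chloro elsewhere on the core, and a single pair for each core cannot separate those two differences.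

The compounds shown leave open whether the swap would behave alike if the halogen sat in the same place on both cores, or if only the trifluoromethyl were exchanged for chloro. They also leave open how fluoro, a methoxy group or an amine at the swapped place would read in this assay, since only chloro and bromo appear there among these compounds.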